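The source may hold more compounds than are shown below. What is called first, only, known or untested is meant among the compounds shown, and "the series" means these compounds.

Compound 2 `COc1ccc(-c2[nH]c3ccc(OC)cc3c2/C=C(\C#N)S(=O)(=O)c2ccccc2)cc1` gives 200 nM in a functional assay on MT4 cells (Homo sapiens) for antiproliferative activity, read by MTT assay, with a stated time of 96 h (a lower number here means that less compound is needed, a higher number that more compound is needed for the effect), and compound 1 `COc1ccc(-c2[nH]c3ccccc3c2/C=C(\C#N)S(=O)(=O)c2ccccc2)cc1` gives 200 nM in this assay, so the two stand level. Adding a methoxy to an aromatic carbon of the core, no change at the digits printed from compound 1 to compound 2 (within the scatter), stayed within the scatter. Compound 3 `COc1ccc2[nH]c(-c3ccccc3)c(/C=C(\C#N)S(=O)(=O)c3ccccc3)c2c1` differs from compound 2 by hydrogen in place of methoxy on an aromatic carbon, on a six-membered aromatic ring of carbon only, para to a large group. Within the data shown here, only one methoxy-for-hydrogen step is known, and it showed no change, so compound 3 is expected to show no change at the digits printed from compound 2 to compound 3 (within the scatter), no shift beyond the scatter. The estimate for compound 3 is 200 nM, with a range from 100 nM to 400 nM.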

Compound 3, half-maximal effective concentration: 1300 nM
Estimate against measurement, compound 3: 6.5-fold (0.81 log units) below; the whole stated range lies below it.
By their numbers in this assay, from the lowest: compounds 1 and 2 (each within the scatter of the next); then compound 3.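

Going from 4-methoxyphenyl to phenyl gives a 6.5-fold higher number from compound 2 to compound 3 (0.81 log units; beyond the scatter) in this assay, so more compound is needed once this methoxy is gone. The earlier swap on the core gave no change at the digits printed from compound 1 to compound 2 (within the scatter) in this assay, so in these compounds the same kind of change matters on the phenyl ring but not on the core. No measurement here explains this difference. As far as these compounds go, whether a hydroxy, an ethoxy or an amine at this place on the ring would restore the lower number remains open. So does whether any group there could take the number lower than the methoxy does.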